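The compounds below may be only part of what the source reports. "The series", "measured", "known", "first", "only" and "open" are said of these compounds alone.

Compound 1, `Nc1nc2cc(Cl)c(Cl)cc2n1COCCO`, was tested in a functional assay on KB cells (Homo sapiens) for inhibition; a lower number here means a stronger inhibitor, a higher number a weaker inhibitor. In this assay compound 1 gives only a limit, > 100000 nM. A second compound, compound 2, `OCCOCn1c(SCc2ccccc2)nc2c(Cl)cc(Cl)cc21`, was tested in the same way. In this assay compound 2 likewise gives only a limit, > 100000 nM. Compound 1 therefore stands at the edge of what the assay can report, and no number separates it from compound 2: both values sit at the same limit, (the limit of > 100000 nM in this assay, at which 2 of the 2 values shown sit). Within the data shown here, no step between two measured compounds is available, so the effect of a single change cannot be read from any measured pair.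

Compound 3, `OCCOCn1c(Br)nc2cc(Cl)c(Cl)cc21`, differs from compound 1 in one place: bromo in place of amino on an aromatic carbon. With both measured values sitting at the limit, nothing suggests that this one exchange would bring the inhibition into the measurable range. Expected is a step that the limit leaves unreadable from compound 1 to compound 3, that is, no change beyond the usual scatter. Compound 3 is expected to come out at 150000 nM, with a range from 30000 nM to 1000000 nM, most probably again reported as a limit rather than a number.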

Compound 3, half-maximal inhibitory concentration: > 100000 nM
Compound 3: no number, only a limit; the forecaster's own chance of this, stated with the estimate: 85%; the middle value lies beyond the limit too.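

In this assay compound 3 gives only a limit, > 100000 nM. Compound 1 also gives only a limit, so the exchange of amino for bromo leaves no readable step between these two compounds: the limit of > 100000 nM in this assay, at which 3 of the 3 values shown sit.

The compounds shown leave open whether any other group at this place, or any other change to the shared core, would bring inhibition into the range where a number can be reported.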